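Urea series: solubility, nitro for methylsulfanyl

The source may report more compounds than this note shows. Statements on the series, on what has been measured and on what is new or still open speak of the compounds shown alone.

Measured so far:
- compound 1, `COc1ccc(NC(=O)Nc2cc(C)nc3ccccc23)cc1`: 19800 nM
- compound 2, `CSc1ccccc1NC(=O)Nc1cc(C)nc2ccccc12`: 21000 nM
- compound 3, `Cc1cc(NC(=O)Nc2ccc(Cl)cc2)c2ccccc2n1`: 1400 nM

The read-out is a physicochemical assay for solubility, at pH 7.4; a higher number here means a more soluble compound, a lower number a less soluble compound. Compound 2 gives the highest of the three numbers, but its gap to compound 1 is within the scatter, so the two cannot be ordered; compound 3 lies well below both. Among the compounds with values here, the only single-point step measured is a 14-fold lower number from compound 1 to compound 3 (1.15 log units; beyond the scatter), a large drop on a different position of the shared core and between different groups.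

Compound 4, `Cc1cc(NC(=O)Nc2ccccc2[N+](=O)[O-])c2ccccc2n1`, differs from compound 2 by nitro in place of methylsulfanyl on an aromatic carbon. Within the data shown here, no measured step covers this change: the step from compound 1 to compound 3 concerns chloro for methoxy and says nothing about a nitro group ortho to a large group. The expectation therefore rests on compound 2 alone, with a wide range and no direction beyond the scatter committed to.

For compound 4 the estimate in this assay is 14000 nM, with a range from 4500 nM to 40000 nM. The step this estimate means is expected to be a 1.5-fold lower number from compound 2 to compound 4 (0.18 log units; within the scatter).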

Compound 4, solubility: 200 nM
Estimate against measurement, compound 4: 70-fold (1.85 log units) above, and the stated range ends above it.
By their numbers in this assay, from the lowest: compound 4; then compound 3; then compounds 1 and 2 (each within the scatter of the next).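

In this assay nitro in place of methylsulfanyl, on an aromatic carbon ortho to a large group, gives a 110-fold lower number from compound 2 to compound 4 (2.02 log units; beyond the scatter) and so shows that this position is not indifferent to the group it carries. Within the data shown here, the only earlier step, chloro in place of methoxy, concerns a different position on the shared core, so this is the first measured change at this place. Nothing shown here accounts for the size of the step.

A single pair cannot separate what belongs to the nitro group from what belongs to this position, and nitro at the position of the earlier step would be needed for that. Also open, as far as these compounds go, is how an amine or a carboxylic acid ortho to a large group would compare with methylsulfanyl and nitro in this assay on this core.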